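Removing the Nitro Group: One Earlier Step as a Guide

This account rests on a few compounds, and the source may have more. Where it says the series, first, only, none or still open, it means among the compounds named here.

Measured compounds:
compound 1 `CCC(C)C(C(=O)Nc1ccc(C(C)=O)cc1)N(C(=O)c1ccccc1)S(=O)(=O)c1ccc([N+](=O)[O-])cc1` — in a functional assay for inhibition, read by spectrophotometry, with a stated time of 20 min, tested at 2 mg/mL (on this read-out higher numbers stand for a stronger effect at the one concentration tested and lower numbers for a weaker effect), compound 1 gives 31.7%
compound 2 `CC(=O)c1ccc(NC(=O)C2CC(O)CN2S(=O)(=O)c2ccc([N+](=O)[O-])cc2)cc1` — in this assay compound 2 gives 57%
compound 3 `CCC(C)C(C(=O)Nc1ccc(C(C)=O)cc1)N(C(=O)c1ccccc1)S(=O)(=O)c1ccccc1` — in this assay compound 3 gives 11.4%

Compound 2 stands highest of the three, and its steps to compound 1 and to compound 3 are both beyond the usual scatter. Compound 1 and compound 2 are built on different cores; how those two cores differ is not broken down here.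

One structural change appears twice in this set. From compound 1 to compound 3 it reads hydrogen in place of nitro on an aromatic carbon and the measurement moved a number 20.3 percentage points lower from compound 1 to compound 3 (beyond the scatter) in this assay. From compound 2 to compound 4 `CC(=O)c1ccc(NC(=O)C2CC(O)CN2S(=O)(=O)c2ccccc2)cc1` the change is hydrogen in place of nitro on an aromatic carbon; the surroundings of the altered carbon are described in the same words for both pairs, so it is taken as the same change on a different core.

With a single earlier example to go on, compound 4 is expected to fall below compound 2 by roughly the same amount as the step from compound 1 to compound 3, because that step was a number 20.3 percentage points lower from compound 1 to compound 3 (beyond the scatter) and pointed downward beyond the scatter. The estimated step from compound 2 to compound 4 is therefore a number 20 percentage points lower from compound 2 to compound 4 (beyond the scatter) in this assay. Going by the values given here, compound 4 is estimated at 37%, with a plausible range from 20% to 54%, the width reflecting that only one precedent exists and on another core.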

Compound 4, a percentage reported as inhibition, at one concentration (the size of the read-out at that concentration, not a potency): 45%
Beside the measured number, compound 4's estimate is 8 percentage points below it; low and high end bracket the measured number.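

In this assay, hydrogen in place of nitro gave a number 12 percentage points lower from compound 2 to compound 4 (beyond the scatter), so on the core of compound 2 the change points the same way as it did on the core of compound 1. Set side by side, the two steps do not differ by more than two such steps would be expected to scatter: the same change on two cores in this assay, a number 20.3 percentage points lower (beyond the scatter) from compound 1 to compound 3 and a number 12 percentage points lower (beyond the scatter) from compound 2 to compound 4, 8.3 percentage points apart, within the scatter of two such steps This shows that, on these two cores, both the downward direction and the size of the step carried over within the scatter, but with only two pairs it does not show that the change would behave the same way on any further core, and it gives no explanation for the drop.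

The compounds shown leave open whether the higher numbers belong to the nitro group specifically or whether another group in the same place, para to a large group, such as a nitrile, an amine or a carboxylic acid, would give a similar number. They also leave open which of the features that separate the two cores, taken one at a time, shape the read-out, and whether the step holds at other concentrations.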